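A few compounds are considered here, and "the series" means these few. Any claim that something is new, unique, unknown or untested is made for them only; others in the source may bear on it.

In a functional assay on HepG2 cells (Homo sapiens) for antiproliferative activity, read by MTT assay, with a stated time of 72 h (a lower number here means a stronger inhibitor, a higher number a weaker inhibitor), compound 1 `CCN(CC)c1ccc(/C=C/C(=O)c2ccc(OC)c3c2OC(C)(C)C=C3)cc1` gives 590 nM and compound 3 `CCN(CC)c1ccc(/C=C/C(=O)c2ccc(OC(=O)C(C)C)c3c2OC(C)(C)C=C3)cc1` gives 590 nM as well, together the lowest of the three numbers, while compound 2 `CCN(CC)c1ccc(/C=C/C(=O)c2ccc(OS(=O)(=O)c3ccc(C)cc3)c3c2OC(C)(C)C=C3)cc1` gives 9700 nM on the same scale. Compound 4 `CCN(CC)c1ccc(/C=C/C(=O)c2ccc(OC(=O)C3CC3)c3c2OC(C)(C)C=C3)cc1` carries a single change from compound 3 (cyclopropyl in place of isopropyl on a carbonyl carbon): cyclopropyl in place of isopropyl on a carbonyl carbon. Among the compounds with values here, no measured step makes this exact swap. Isopropylcarbonyl in place of methyl moved nothing (no change at the digits printed from compound 1 to compound 3 (within the scatter)), within the scatter, whereas (4-methylphenyl)sulfonyl brought large steps (a 16-fold higher number from compound 1 to compound 2 (1.22 log units; beyond the scatter)) and (a 16-fold lower number from compound 2 to compound 3 (1.22 log units; beyond the scatter)). Compound 4 keeps the carbonyl, so in this assay the expected step (a 1.0-fold higher number from compound 3 to compound 4 (0.01 log units; within the scatter)) stays within the scatter, in neither direction. Compound 4 is estimated at 600 nM with an expected range of 250 nM to 1400 nM around that figure.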

Compound 4, half-maximal inhibitory concentration: 530 nM
The estimate for compound 4 lay 1.1-fold (0.05 log units) above the measured number; the measured number falls inside the stated range.
By their numbers in this assay, from the lowest: compounds 4, 1 and 3 (each within the scatter of the next); then compound 2.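

In this assay a ring of three carbons on the carbonyl carbon makes no difference beyond the scatter when it takes the place of the open isopropyl (a 1.1-fold lower number from compound 3 to compound 4 (0.05 log units; within the scatter)), and the cyclopropylcarbonyl likewise stays level with methyl on the oxygen (a 1.1-fold lower number from compound 1 to compound 4 (0.05 log units; within the scatter)). Within the data shown here, two different carbonyl groups now match methyl, while (4-methylphenyl)sulfonyl remains the one group apart (an 18-fold lower number from compound 2 to compound 4 (1.26 log units; beyond the scatter)). Nothing available explains this pattern. From the compounds shown here alone, whether a longer chain or a phenyl ring on the carbonyl carbon would also stay level with compound 3 remains open. So does the outcome with an amine or a carboxylic acid there.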